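Chloro to fluoro on the aryl group at ring nitrogen

The source may report more compounds than this note shows. Statements on the series, on what has been measured and on what is new or still open speak of the compounds shown alone.

Of the compounds shown here, two have numbers so far. Compound 1 `CC(C)(C)C1=NN(c2ccc(Br)cc2)C(c2ccc(O)cc2)C1` gives 93.2% in an assay on isolated protein for inhibition of protein kinase C zeta type (Homo sapiens), with a stated time of 4 min, tested at 62.5 uM; a lower number here means less inhibition, a higher number more inhibition at the concentration tested (going by the name of the read-out). Compound 2 `CC(C)(C)C1=NN(c2cccc(Cl)c2)C(c2ccc(O)cc2)C1` gives 96.8% in this assay. Compound 2 has compound 1 as its only neighbour on the numbers shown, and the step of a number 3.6 percentage points higher from compound 1 to compound 2 (within the scatter) lies within the scatter, so the two cannot be set apart. Compound 3 `CC(C)(C)C1=NN(c2cccc(F)c2)C(c2ccc(O)cc2)C1` differs from compound 2 by fluoro in place of chloro on an aromatic carbon. Among the compounds with values here, no measured step exchanges one halogen for another on the same aromatic carbon; the one step in hand, a number 3.6 percentage points higher from compound 1 to compound 2 (within the scatter), changed both the halogen and its place and stayed within the scatter. Both measured compounds sit near the top of the scale, which leaves little room upward. The expected step is therefore a number 2.8 percentage points lower from compound 2 to compound 3 (within the scatter), not beyond the scatter. Compound 3 is estimated at 94%, between 84% and 99%, in this assay.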

Compound 3, a percentage reported as inhibition, at one concentration (the size of the read-out at that concentration, not a potency): 98.1%
Compound 3: the middle estimate sits 4.1 percentage points below what was measured; the range from low to high includes it.
By their numbers in this assay, from the lowest: compounds 1, 2 and 3 (each within the scatter of the next).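

In this assay, the exchange of one halogen for another on the same aromatic carbon gives a number 1.3 percentage points higher from compound 2 to compound 3 (within the scatter) and so does not set 3-chlorophenyl and 3-fluorophenyl apart at this position. The step of a number 4.9 percentage points higher from compound 1 to compound 3 (within the scatter) likewise leaves 3-fluorophenyl and 4-bromophenyl unresolved, and all three compounds sit near the top of the scale at the single concentration tested, which gives no potency. No measurement at hand offers an explanation for these numbers.

Open, going by these compounds, is whether a group other than a halogen at this place, such as methoxy, an amine or a carboxylic acid, would give a number beyond the scatter. Also open, on these data alone, is whether these compounds would separate at a lower concentration, away from the top of the scale.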